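The source may report more compounds than this note shows. Statements on the series, on what has been measured and on what is new or still open speak of the compounds shown alone.

Measured compounds:
Compound 1, `COc1ccc(-c2ccc(-c3ccc(C(=N)N)cc3)s2)cc1`: 1410 nM
Compound 2, `N=C(N)c1ccc(-c2ccc(-c3cc(Cl)cc(Cl)c3)s2)cc1`: 1540 nM

Both were tested in a functional assay on M14 cells (Homo sapiens) for inhibition, read by sulforhodamine B assay, with a stated time of 48 h; a higher number here means a weaker inhibitor of growth, a lower number a stronger inhibitor of growth. Compound 1 gives the lower of the two numbers, but compound 2 sits so close that the two values cannot be told apart, and neither can be called the stronger inhibitor of growth. Compound 3, `N=C(N)c1ccc(-c2ccc(-c3ccc(F)cc3)s2)cc1`, has not yet been measured. It differs from compound 1 in a single place: fluoro in place of methoxy on an aromatic carbon. Among the compounds with values here, no measured pair shows what this particular change does, so the expectation rests only on compound 1 and compound 2, whose values lie at about the same level. In this assay the expected change, a 1.3-fold higher number from compound 1 to compound 3 (0.11 log units; within the scatter), is small and in no clear direction beyond the scatter. Compound 3 is therefore expected to give about 1800 nM, with a likely range from 700 nM to 4500 nM.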

Compound 3, concentration for 50% growth inhibition: 1600 nM
Estimate against measurement, compound 3: 1.1-fold (0.05 log units) above, and the stated range covers the measured number.
By their numbers in this assay, from the lowest: compounds 1, 2 and 3 (each within the scatter of the next).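

Fluoro in place of methoxy on an aromatic carbon, para to a large group, gives a 1.1-fold higher number from compound 1 to compound 3 (0.05 log units; within the scatter) in this assay and is the first direct reading of a change at this position. The two values cannot be told apart, so this pair gives no sign that growth inhibition here depends on the methoxy group or its oxygen, even though the fluoro group has fewer heavy atoms and no hydrogen-bond acceptor. Nothing measured explains why the swap makes no visible difference.

The compounds shown leave open whether any group at this position can move the number beyond the scatter, such as an amine, a carboxylic acid or a longer alkoxy chain. They also leave open whether the same swap would behave alike on a different core.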